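The source may report more compounds than this note shows. Statements on the series, on what has been measured and on what is new or still open speak of the compounds shown alone.

The measured compounds:
compound 1, `CCCCCCCCc1cc2cn([C@H]3C[C@H](O)[C@@H](CO)O3)c(=O)nc2o1`, gives > 50000 nM in a functional assay on HEL cells (Homo sapiens) for cytotoxicity, read by microscopy; on this read-out lower numbers stand for higher toxicity in this test and higher numbers for lower toxicity in this test;
compound 2, `C=CCCCCCCCCc1cc2cn([C@H]3C[C@H](O)[C@@H](CO)O3)c(=O)nc2o1`, gives > 50000 nM in this assay.

The value for compound 1 is a limit of the assay, not a number. The same holds for compound 2. Compound 1 therefore stands at the upper edge of what the test reports: the limit of > 50000 nM in this assay, at which 2 of the 2 values shown sit. No toxicity was seen for it up to that edge.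

Compound 3, `C#CCCCCc1cc2cn([C@H]3C[C@H](O)[C@@H](CO)O3)c(=O)nc2o1`, has not yet been measured. It differs from compound 1 by ethynyl in place of butyl on a saturated chain carbon, four bonds along the chain from an aromatic carbon, so the chain becomes shorter and ends in a triple bond.

Among the measured compounds shown here, only one measured step exists, a step that the two limits leave unreadable from compound 1 to compound 2. It cannot be read; both its ends sit at the limit, so neither its size nor its direction is known. For the measured compounds named here, no measured step bears directly on a shortened chain with a triple bond.

Going by the values given here, with both measured values sitting at the limit, compound 3 is expected to sit there as well, which means a step that the limit leaves unreadable from compound 1 to compound 3 that is no step at all in this assay. The estimate for compound 3 is 60000 nM, with a range from 25000 nM to 150000 nM.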

Compound 3, minimum cytotoxic concentration: > 200000 nM
Compound 3 gave a limit, no number; the forecaster's own chance of this, stated with the estimate: 80%; middle value at least 3.3-fold (0.52 log units) away from the limit.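

In this assay compound 3 gives > 200000 nM, and this value is a limit, not a number. Among the compounds shown here, compound 1, compound 2 and compound 3 all stand at limits, so no step among them can be read. The compounds shown leave open at what concentration, if any, each of them would become toxic to these cells.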